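Chloro for Methyl on Compound 2

The source may report more compounds than this note shows. Statements on the series, on what has been measured and on what is new or still open speak of the compounds shown alone.

In a functional assay on MDA-MB-231 cells (Homo sapiens) for antiproliferative activity, read by MTT assay, with a stated time of 24 h (a lower number here means a stronger inhibitor, a higher number a weaker inhibitor), compound 1 `Cc1cccc(NNC(=O)c2ccccc2NS(=O)(=O)c2cnc(O)nc2O)c1` stands at > 20000 nM which is a limit and not a number. For the measured compounds named here, compound 2 `Cc1ccccc1C(=O)NNC(=O)c1ccccc1NS(=O)(=O)c1cnc(O)nc1O` gives 5570 nM as the only true number so far. Compound 3 `O=C(NNC(=O)c1ccccc1NS(=O)(=O)c1cnc(O)nc1O)c1ccccc1Cl` differs from it by chloro in place of methyl on an aromatic carbon with chloro in place of methyl on an aromatic carbon, ortho to a large group. Going by the values given here, the only measured step is an at least 3.5-fold lower number from compound 1 to compound 2 (0.55 log units; beyond the scatter) and it exchanged a whole group, so it offers little guidance on so small a swap. The expected change is a 1.1-fold lower number from compound 2 to compound 3 (0.05 log units; within the scatter) and no shift beyond the scatter is anticipated in this assay here. Compound 3 is estimated at 5000 nM with a range from 2000 nM to 13000 nM and still awaits measurement.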

Compound 3, half-maximal inhibitory concentration: 8310 nM
For compound 3 the middle estimate is 1.7-fold (0.22 log units) below the measured one; measured number inside the range.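

In this assay, chloro in place of methyl on this aromatic carbon, ortho to a large group, gives a 1.5-fold higher number from compound 2 to compound 3 (0.17 log units; within the scatter), so this swap does not separate the two groups. With (2-chlorophenyl)carbonyl in place of 3-methylphenyl, the result is an at least 2.4-fold lower number from compound 1 to compound 3 (0.38 log units; beyond the scatter), so the lower number seen with the 2-methylphenyl compound also holds with chloro. Compound 1 gives a limit and not a number: the limit of > 20000 nM in this assay, at which 1 of the 3 values shown sits.

From the compounds shown here alone, whether a methoxy group or an amine on this same aromatic carbon would shift the number beyond the scatter remains open.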